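A Methyl Group on the Ring, in Two Settings

A few compounds are considered here, and "the series" means these few. Any claim that something is new, unique, unknown or untested is made for them only; others in the source may bear on it.

Compound 3 `CC(=O)Nc1cc(-c2ccc(OC[C@@H](N)CC(C)C)cc2)ccn1` carries a (2-amino-4-methylpentyl)oxy group on a six-membered aromatic ring of carbon only. In an assay on isolated protein for inhibition of AP2-associated protein kinase 1 (Homo sapiens), with a stated time of 3 h, in the presence of a further agent that is not named here (on this read-out higher numbers stand for weaker inhibition and lower numbers for stronger inhibition), compound 3 gives 4.6 nM. Compound 1 `CC(=O)Nc1cc(-c2ccc(OC[C@@H](N)CC(C)C)c(C)c2)ccn1` differs from it by methyl in place of hydrogen on an aromatic carbon, and in this assay compound 1 gives 0.4 nM, a step of a 12-fold lower number from compound 3 to compound 1 (1.06 log units; beyond the scatter). Compound 2 `COC(=O)Nc1cc(-c2ccc(OC[C@@](C)(N)CC(C)C)nc2)ccn1` rests on another core; the difference between the two cores is not broken down here. In this assay compound 2 gives 28 nM. Compound 4 `COC(=O)Nc1cc(-c2cnc(OC[C@@](C)(N)CC(C)C)cc2C)ccn1` is not yet measured and differs from compound 2 by methyl in place of hydrogen on an aromatic carbon. This is the same kind of change as from compound 3 to compound 1, not the same: here the ring holds one nitrogen and the methyl sits ortho to a large group and meta to the (2-amino-2,4-dimethylpentyl)oxy group, whereas in compound 1 it sits ortho to the (2-amino-4-methylpentyl)oxy group and meta to the large group. A gain is expected for compound 4 because the step of a 12-fold lower number from compound 3 to compound 1 (1.06 log units; beyond the scatter) was large, yet a smaller one given the different surroundings, so for compound 4 the expected step is a 3.1-fold lower number from compound 2 to compound 4 (0.49 log units; beyond the scatter). Compound 4 is estimated to give about 9 nM in this assay, likely between 3 nM and 30 nM.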

Compound 4, half-maximal inhibitory concentration: 490 nM
Compound 4: the middle estimate sits 54-fold (1.74 log units) below what was measured; measured number above the stated range.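

In this assay methyl on the ring of compound 2 gives an 18-fold higher number from compound 2 to compound 4 (1.24 log units; beyond the scatter), so inhibition weakens here, whereas the same kind of change strengthened it on the other core. A gain from this change on one core therefore did not carry over to the other: the same change on two cores in this assay, a 12-fold lower number (1.06 log units; beyond the scatter) from compound 3 to compound 1 and an 18-fold higher number (1.24 log units; beyond the scatter) from compound 2 to compound 4, 200-fold (2.30 log units) apart, beyond the scatter of two such steps

This does not show what lies behind the reversal: the two pairs differ in the ring, in where the methyl sits and in the chain, and the data cannot separate these differences.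

Still open, on these data alone, is whether the loss belongs to methyl alone or would also follow from a chlorine atom or an ethyl group at the same place. As far as these compounds go, whether methyl elsewhere on the ring of compound 2 would give a gain also stays open.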